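The compounds below may be only part of what the source reports. "The series", "measured", "known", "first", "only" and "open" are said of these compounds alone.

Compound 1 `Cc1nn(-c2ncnc3nc[nH]c23)c2c1C(C(=O)NCc1ccccc1)CC(=O)N2`: 2930 nM in a functional assay on HEK293 cells for agonist activity at G-protein coupled receptor 39 (Homo sapiens), read by scintillation proximity assay and inositol phosphate accumulation, with a stated time of 75 min; on this read-out higher numbers stand for an effect only at larger amounts of compound and lower numbers for an effect already at smaller amounts.
Compound 2 `Cc1nn(-c2ncnc3nc[nH]c23)c2c1C(OCc1ccc(C(C)C)cc1)CC(=O)N2`: 1690 nM in this assay.
Compound 3 `Cc1nn(-c2ncnc3nc[nH]c23)c2c1C(C(=O)N(C)c1nccs1)CC(=O)N2`: 3300 nM in this assay.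

Compound 1 has the second highest of the three numbers, but its gaps to compound 3 and to compound 2 are both within the scatter, so no order among the three can be claimed. Compound 4 `Cc1nn(-c2ncnc3nc[nH]c23)c2c1C(OCc1ccccc1Cl)CC(=O)N2` differs from compound 1 by (2-chlorobenzyl)oxy in place of benzylcarbamoyl on a saturated ring carbon. Going by the values given here, the only measured single step, a 1.1-fold higher number from compound 1 to compound 3 (0.05 log units; within the scatter), alters a different part of the molecule and stayed within the scatter, so it offers little guidance. Among the measured compounds the closest structural relative of compound 4 is compound 2, which gives 1690 nM, within the scatter of compound 1. The step is therefore expected to be small, a 1.5-fold lower number from compound 1 to compound 4 (0.17 log units; within the scatter). Compound 4 is estimated at 2000 nM, between 700 nM and 6000 nM.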

Compound 4, half-maximal effective concentration: 47 nM
The estimate for compound 4 lay 43-fold (1.63 log units) above the measured number; the measured number lies below the stated range.
By their numbers in this assay, from the lowest: compound 4; then compounds 2, 1 and 3 (each within the scatter of the next).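

At this saturated ring carbon the group decides the outcome in this assay: replacing either carbamoyl group with (2-chlorobenzyl)oxy gives a 62-fold lower number from compound 1 to compound 4 (1.79 log units; beyond the scatter) and a 70-fold lower number from compound 3 to compound 4 (1.85 log units; beyond the scatter). An oxygen link alone is not enough, since compound 2 also has one, and the aromatic group on that link still gives a 36-fold lower number from compound 2 to compound 4 (1.56 log units; beyond the scatter). Nothing measured here explains these steps.

On these data alone, it remains open whether plain benzyloxy or (4-chlorobenzyl)oxy would keep this low number. A longer chain, such as 2-phenylethoxy, is also untested among the compounds shown.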